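Benzyloxy gives way to diethylamino in a level series

The source may report more compounds than this note shows. Statements on the series, on what has been measured and on what is new or still open speak of the compounds shown alone.

Of the compounds shown here, three built on a shared core have been measured in a functional assay on MCF7 cells (Homo sapiens) for cytotoxicity, read by colorimetric assay and MTT assay (on this read-out lower numbers stand for stronger inhibition and higher numbers for weaker inhibition), so far. Compound 1 (`COc1ccc(-c2cc3c(OC)cc(OC)cc3n(CC(=O)OCc3ccccc3)c2=O)cc1`) gives 10000 nM in that read-out. Compound 2 (`COC(=O)CCn1c(=O)c(-c2ccc(OC)cc2)cc2c(OC)cc(OC)cc21`) gives 10000 nM there as well. Compound 3 (`COc1ccc(-c2cc3c(OC)cc(OC)cc3n(CCC(=O)OCc3ccccc3)c2=O)cc1`) gives 10000 nM and so stands level with the other two.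

The next compound keeps the core and the chain of compound 3 and alters only the far end of the chain. In compound 4 (`CCN(CC)C(=O)CCn1c(=O)c(-c2ccc(OC)cc2)cc2c(OC)cc(OC)cc21`) diethylamino stands in place of benzyloxy on a carbonyl carbon (diethylamino in place of benzyloxy on a carbonyl carbon), which turns benzyloxycarbonyl into diethylcarbamoyl.

The closest measured precedent is the exchange on that same chain, which gave no change at the digits printed from compound 2 to compound 3 (within the scatter) for phenyl in place of hydrogen. The two changes to the group on the nitrogen of the core gave no change at the digits printed from compound 1 to compound 2 (within the scatter) and no change at the digits printed from compound 1 to compound 3 (within the scatter) without any shift. Among the measured compounds shown here, no measured compound carries a nitrogen group on this carbonyl carbon, so the evidence is indirect. With all three steps flat, the step expected in this assay is no change at the digits printed from compound 3 to compound 4 (within the scatter) and nothing beyond the scatter, with no favoured direction. Compound 4 is therefore expected at 10000 nM (estimated range 4000 nM to 20000 nM) on this reasoning.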

Compound 4, half-maximal inhibitory concentration: 10000 nM
Estimate against measurement, compound 4: no gap at the digits printed; the range from low to high includes it.
By their numbers in this assay, from the lowest: compounds 1, 2, 3 and 4 (each within the scatter of the next).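

In this assay, among the compounds shown here, the carbonyl carbon at the end of the chain now carries a nitrogen group for the first time, and diethylamino in place of benzyloxy gives no change at the digits printed from compound 3 to compound 4 (within the scatter), so this exchange, which also removes the six-membered aromatic ring of benzyloxy, leaves the read-out level. The same holds when diethylamino is set against the smaller methoxy, with no change at the digits printed from compound 2 to compound 4 (within the scatter), and when (diethylcarbamoyl)methyl is set against benzyloxycarbonyl on the saturated chain carbon, with no change at the digits printed from compound 1 to compound 4 (within the scatter), so neither the benzyloxycarbonyl nor the methoxycarbonyl end of the chain stands apart from diethylcarbamoyl here. There is no supporting measurement that would account for this flat result.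

The compounds shown leave open whether any group on this carbonyl carbon can move the value away from this level, for instance the hydroxyl of a free carboxylic acid, or a cyclic amine such as piperidine or morpholine in place of diethylamino. They also leave open whether a longer chain on the nitrogen of the core, or a free amine at its end, would separate itself from these four compounds.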